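The source may report more compounds than this note shows. Statements on the series, on what has been measured and on what is new or still open speak of the compounds shown alone.

Measured in a functional assay on SMMC-7721 cells (Homo sapiens) for cytotoxicity, read by MTT assay, with a stated time of 24 h; a higher number here means a weaker inhibitor, a lower number a stronger inhibitor:
compound 1 `O=C1/C(=C/c2ccc(F)cc2)CN(S(=O)(=O)c2ccc(F)cc2)C/C1=C\c1ccc(F)cc1` gives 14700 nM
compound 2 `O=C1/C(=C/c2ccc(F)cc2)CN(S(=O)(=O)c2ccc(Br)cc2)C/C1=C\c1ccc(F)cc1` gives 11500 nM

For the measured compounds named here, compound 2 and compound 1 lie within the scatter of each other; the one measured step, a 1.3-fold lower number from compound 1 to compound 2 (0.11 log units; within the scatter), is all the series offers as a guide. Compound 3 `CC(=O)Nc1ccc(S(=O)(=O)N2C/C(=C\c3ccc(F)cc3)C(=O)/C(=C/c3ccc(F)cc3)C2)cc1` differs from compound 2 by acetamido in place of bromo on an aromatic carbon. Going by the values given here, only that halogen exchange bears on the new step, and it was small. The acetamido replacement is a larger change than anything measured, so no shift in this assay beyond the scatter is expected, but with a wide range. Compound 3 is therefore estimated at 13000 nM, between 5500 nM and 32000 nM, an expected step of a 1.1-fold higher number from compound 2 to compound 3 (0.05 log units; within the scatter).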

Compound 3, half-maximal inhibitory concentration: 9800 nM
Compound 3: middle estimate off by 1.3-fold (0.12 log units), on the high side, within the range that was stated.
By their numbers in this assay, from the lowest: compounds 3, 2 and 1 (each within the scatter of the next).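

On the aromatic carbon para to a large group, the change from 4-bromophenyl to 4-acetamidophenyl adds heavy atoms, a hydrogen-bond donor and a hydrogen-bond acceptor, yet this assay shows a 1.2-fold lower number from compound 2 to compound 3 (0.07 log units; within the scatter) and a 1.5-fold lower number from compound 1 to compound 3 (0.18 log units; within the scatter). A non-halogen group therefore leaves the number within the scatter of both halogen compounds, which the fluoro-to-bromo exchange alone could not show. No evidence on hand bears on this result.

Going by these compounds, whether an amine or a carboxylic acid at this carbon would give a step beyond the scatter remains open. So does the effect of a longer chain in place of acetamido.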